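This account rests on a few compounds, and the source may have more. Where it says the series, first, only, none or still open, it means among the compounds named here.

Measured compounds in a functional assay on CCRF-CEM cells (Homo sapiens) for cytotoxicity, read by sulforhodamine B assay, with a stated time of 48 h, tested at 10 uM; on this read-out lower numbers stand for a stronger effect and higher numbers for a weaker effect at the one concentration tested:
- compound 1, `COc1cc(-c2cc(/C=C/C(=O)c3ccc(N)cc3)[nH]n2)cc(OC)c1OC`, gives -22%
- compound 2, `COc1ccc(-c2cc(/C=C/C(=O)c3ccc(N)cc3)[nH]n2)cc1OC`, gives -8%
- compound 3, `COc1cc(C(=O)/C=C/c2cc(-c3cc(OC)c(OC)c(OC)c3)n[nH]2)cc(OC)c1OC`, gives -7%

Compound 1 and compound 2 share a core and differ in one place only: hydrogen in place of methoxy on an aromatic carbon. On this change the read-out moved by a number 14 percentage points higher from compound 1 to compound 2 (beyond the scatter), a step that lies beyond the usual scatter. Compound 3 carries a different core; how that core differs from the core of compound 1 is not broken down here, so the two values can only be set side by side. The number for compound 3 stands near that of compound 2, within the scatter, while it lies well apart from that of compound 1.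

Compound 4, `COc1ccc(-c2cc(/C=C/C(=O)c3cc(OC)c(OC)c(OC)c3)[nH]n2)cc1OC`, has not been measured. It arises from compound 3 by the same change that turned compound 1 into compound 2: hydrogen in place of methoxy on an aromatic carbon. Since the place line reads the same in both cases, the two changes are the same change, made on two different cores.

Among the measured compounds shown here, the expectation for compound 4 rests on the one step available, the move from compound 1 to compound 2, which was a number 14 percentage points higher from compound 1 to compound 2 (beyond the scatter). Placing a step of comparable size on compound 3, the same change is estimated to carry the read-out from compound 3 to compound 4 by a number 12 percentage points higher from compound 3 to compound 4 (beyond the scatter). This is an expectation drawn from a single precedent on another core, so its range is held wide. In this assay compound 4 is therefore estimated at 5%, with the likely span from -15% to 25%.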

Compound 4, a percentage reported as activity, at one concentration (the size of the read-out at that concentration, not a potency): -15%
For compound 4 the middle estimate is 20 percentage points above the measured one, within the range that was stated.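

In this assay, among the compounds shown here, putting hydrogen in place of methoxy on the core of compound 3 gave a number 8 percentage points lower from compound 3 to compound 4 (within the scatter), so on this core the change produced no step that can be told apart from the scatter. Set beside the earlier step on the core of compound 1, the result shows that the change did not carry over from one core to the other: the same change on two cores in this assay, a number 14 percentage points higher (beyond the scatter) from compound 1 to compound 2 and a number 8 percentage points lower (within the scatter) from compound 3 to compound 4, 22 percentage points apart, beyond the scatter of two such steps This shows that, in this series, the step seen on one core was no guide to the step on the other, but it does not show why the two differ, and with one pair on each core it gives no rule for any further core.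

The compounds shown leave open how a hydroxy group, a fluorine atom or an ethoxy group in the same place would read on either core, and whether any of them would separate the two cores as clearly. They also leave open whether the change would follow the pair of compound 1 and compound 2 or the pair of compound 3 and compound 4 on a core carrying a carboxylic acid or a longer chain.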